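The source may report more compounds than this note shows. Statements on the series, on what has been measured and on what is new or still open speak of the compounds shown alone.

Going by the values given here, compound 3 `COc1ccc(Cn2cnc3c(Nc4cccc(Cl)c4)nc(N[C@H]4CC[C@H](N)CC4)nc32)cc1` gives 4800 nM in a functional assay on MCF7 cells (Homo sapiens) for inhibition, read by fluorescence, with a stated time of 72 h (on this read-out higher numbers stand for weaker inhibition of growth and lower numbers for stronger inhibition of growth), which is the second highest of the three numbers measured so far. Compound 2 `CCCCCCn1cnc2c(Nc3cccc(Cl)c3)nc(N[C@H]3CC[C@H](N)CC3)nc21` gives 2700 nM in this assay, and compound 1 `CC(C)CCn1cnc2c(Nc3cccc(O)c3)nc(N[C@H]3CC[C@H](N)CC3)nc21` gives 12600 nM in this assay. The unmeasured compound 4 `CC(C)CCn1cnc2c(Nc3cccc(Cl)c3)nc(N[C@H]3CC[C@H](N)CC3)nc21` differs from compound 3 by isobutyl in place of 4-methoxyphenyl on a saturated chain carbon bound to an aromatic nitrogen. Among the compounds with values here, the one measured step that bears on this change is a 1.8-fold higher number from compound 2 to compound 3 (0.25 log units; within the scatter), where swapping the group on a saturated chain carbon bound to an aromatic nitrogen stayed within the scatter. Compound 4 again carries a plain alkyl chain at that place, like compound 2, so little movement beyond the scatter is expected. Compound 4 is therefore estimated to give 3500 nM in this assay, a step of a 1.4-fold lower number from compound 3 to compound 4 (0.14 log units; within the scatter), within a range from 1500 nM to 8000 nM.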

Compound 4, concentration for 50% growth inhibition: 2100 nM
The estimate for compound 4 lay 1.7-fold (0.22 log units) above the measured number, and the stated range covers the measured number.
By their numbers in this assay, from the lowest: compounds 4, 2 and 3 (each within the scatter of the next, the first and the last beyond it); then compound 1.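

In this assay, 4-methoxybenzyl giving way to isopentyl produces a 2.3-fold lower number from compound 3 to compound 4 (0.36 log units; beyond the scatter), so the group at this place can move the number beyond the scatter, which the earlier step from a straight chain to 4-methoxybenzyl did not show. Among the plain chains, a 1.3-fold lower number from compound 2 to compound 4 (0.11 log units; within the scatter) shows that branched and straight alkyl groups cannot be told apart here. With the chain held constant, chloro in place of hydroxy on an aromatic carbon gives a 6.0-fold lower number from compound 1 to compound 4 (0.78 log units; beyond the scatter).

The data shown offer no explanation for these steps. As far as these compounds go, whether a carboxylic acid or an amine on the chain, or fluoro in place of chloro, would shift the number remains open.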